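The compounds below may be only part of what the source reports. "The series", "measured", "known", "first", "only" and "open" are said of these compounds alone.

Measured in a functional assay on HEK293 cells for antagonist activity at P2X purinoceptor 7 (Homo sapiens); a lower number here means a stronger inhibitor, a higher number a weaker inhibitor:
Compound 1 `O=C(NCC1(O)CCCC(F)(F)C1)c1cc(-c2ncc(F)cn2)ccc1Cl` gives 51 nM in this assay.
Compound 2 `N#Cc1cccc(-c2ccc(Cl)c(C(=O)NCC3(O)CCCCCC3)c2)n1` gives 232 nM in this assay.

Among the measured compounds shown here, compound 2 holds the higher of the two numbers so far; the nearest is compound 1, and the gap between the two lies beyond the usual scatter. For the measured compounds named here, the two compounds differ in more than one place, so their values show only that compound 2 is the weaker inhibitor of the pair in this assay.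

Compound 3 `O=C(NCC1(O)CCCCCC1)c1cc(-c2ccc(CO)cn2)ccc1Cl` is the next compound to be measured in this assay. It differs from compound 2 by 5-(hydroxymethyl)pyridin-2-yl in place of 6-cyanopyridin-2-yl on an aromatic carbon. Going by the values given here, no single-point step between measured compounds gives a scale for such an exchange on that ring, so the expectation is a step of modest size, without a clear direction beyond the scatter, as a step of a 1.1-fold higher number from compound 2 to compound 3 (0.03 log units; within the scatter). Compound 3 is therefore estimated at 250 nM, in the range 80 nM to 800 nM.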

Compound 3, half-maximal inhibitory concentration: 17 nM
For compound 3 the middle estimate is 15-fold (1.17 log units) above the measured one; the whole stated range lies above it.
By their numbers in this assay, from the lowest: compound 3; then compound 1; then compound 2.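

In this assay, among the compounds shown here, the aromatic carbon para to the chloro group proves sensitive to the pyridine attached there: 5-(hydroxymethyl)pyridin-2-yl in place of 6-cyanopyridin-2-yl gives a 14-fold lower number from compound 2 to compound 3 (1.14 log units; beyond the scatter) as the first single-place comparison, and a large one. The exchange removes a nitrile, brings in a hydroxymethyl group with a hydrogen-bond donor, and changes where the substituent sits on the pyridine, so the step belongs to the whole exchange and not to any one of these features. No measurement at hand accounts for the step.

Still open, from the compounds shown here alone, is whether the lower number follows the hydroxymethyl group or its place on the pyridine, which 6-(hydroxymethyl)pyridin-2-yl and 5-cyanopyridin-2-yl would separate. Also open, going by these compounds, is how other groups at that pyridine carbon compare, such as methoxymethyl, aminomethyl or a carboxylic acid.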